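A Methyl Added to the Chain of Compound 1

This account rests on a few compounds, and the source may have more. Where it says the series, first, only, none or still open, it means among the compounds named here.

Compound 1 `CCC/N=C(\C)c1c(O)c2ccccc2[nH]c1=O`: in an assay on isolated protein for inhibition of myosin-2 (Bos taurus), read by spectrophotometry, with a stated time of 24 min (a higher number here means a weaker inhibitor, a lower number a stronger inhibitor), compound 1 reaches only the limit of the assay, >= 100000 nM.
Compound 2 `C/C(=N\Cc1cccc(C)c1)c1c(O)c2ccccc2oc1=O`: in this assay compound 2 gives 4900 nM.
Compound 3 `C/C(=N\Cc1ccccn1)c1c(O)c2ccccc2oc1=O`: in this assay compound 3 gives 22000 nM.

Compound 1 thus stands at the limit, and no number is known for it (the limit of >= 100000 nM in this assay, at which 1 of the 3 values shown sits). Compound 4 `C/C(=N\CC(C)C)c1c(O)c2ccccc2[nH]c1=O` differs from compound 1 by methyl in place of hydrogen on a saturated chain carbon bound to two saturated chain carbons. Among the compounds with values here, the single measured step, a 4.5-fold higher number from compound 2 to compound 3 (0.65 log units; beyond the scatter), concerns a ring swap on another core and so does not bear on this change. With compound 1 at the limit and only one carbon added, compound 4 is expected to remain near that limit, which is an expected step of a number no higher from compound 1 to compound 4 (the limit leaves the size open). The estimate for compound 4 is 100000 nM, expected to lie between 30000 nM and 300000 nM.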

Compound 4, half-maximal inhibitory concentration: >= 100000 nM
Compound 4: only a limit was reported; the forecaster's own chance of this, stated with the estimate: 70%; the middle value lies on the limit itself.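

No step can be read between compound 1 and compound 4, since each gives only a limit in this assay: the limit of >= 100000 nM in this assay, at which 2 of the 4 values shown sit.

The compounds shown leave open how strongly either one inhibits, and whether the added methyl changes the number at all.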